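The source may report more compounds than this note shows. Statements on the series, on what has been measured and on what is new or still open speak of the compounds shown alone.

Working notes on the series. Compound 1 `O=C(c1ccc(Cl)cc1)N1CCC(NS(=O)(=O)c2cc(S(=O)(=O)c3ccccc3)ccc2C(F)(F)F)CC1` gives 1800 nM in an assay on U2OS cells for inhibition of secreted frizzled-related protein 1 (Homo sapiens), read by a luciferase reporter, with a stated time of 18 h; on this read-out higher numbers stand for an effect only at larger amounts of compound and lower numbers for an effect already at smaller amounts; compound 2 `O=C(c1cccnc1)N1CCC(NS(=O)(=O)c2cc(S(=O)(=O)c3ccccc3)ccc2C(F)(F)F)CC1` gives 120 nM; compound 3 `O=S(=O)(NC1CCN(S(=O)(=O)c2ccccc2)CC1)c1cc(S(=O)(=O)c2ccccc2)ccc1C(F)(F)F` gives 210 nM. The measured steps of a 15-fold lower number from compound 1 to compound 2 (1.18 log units; beyond the scatter) and an 8.6-fold lower number from compound 1 to compound 3 (0.93 log units; beyond the scatter) were both beyond the scatter, while a 1.8-fold higher number from compound 2 to compound 3 (0.24 log units; within the scatter) was within it, so compound 3 stands second highest of the three numbers, close to compound 2 and well below compound 1. Compound 4 `O=C(O)c1ccc(S(=O)(=O)N2CCC(NS(=O)(=O)c3cc(S(=O)(=O)c4ccccc4)ccc3C(F)(F)F)CC2)cc1` differs from compound 3 by carboxy in place of hydrogen on an aromatic carbon. Going by the values given here, none of the measured steps touches this phenylsulfonyl ring; all three alter the group on the ring nitrogen, so no measured step bears on the change directly. Compound 4 is therefore expected near compound 3, with a 1.4-fold higher number from compound 3 to compound 4 (0.15 log units; within the scatter) not beyond the scatter. The estimate for compound 4 is 300 nM, within 80 nM to 1200 nM.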

Compound 4, half-maximal effective concentration: 110 nM
For compound 4 the middle estimate is 2.7-fold (0.44 log units) above the measured one; measured number inside the range.
By their numbers in this assay, from the lowest: compounds 4, 2 and 3 (each within the scatter of the next); then compound 1.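

Carboxy on the phenylsulfonyl ring, para to a large group, is accepted in this assay (a 1.9-fold lower number from compound 3 to compound 4 (0.28 log units; within the scatter)), so this position takes the added heavy atoms without a change beyond the scatter. The (4-carboxyphenyl)sulfonyl group reads level with the (pyridin-3-yl)carbonyl group (a 1.1-fold lower number from compound 2 to compound 4 (0.04 log units; within the scatter)) and stands well apart from the (4-chlorophenyl)carbonyl group (a 16-fold lower number from compound 1 to compound 4 (1.21 log units; beyond the scatter)). Nothing at hand accounts for these steps.

Still open, going by these compounds, is whether a methyl ester or an amine at the same place would read the same. On these data alone, it is also open whether carboxy elsewhere on this ring would be accepted.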